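Extending the ether substituent on the triazine core

The compounds below may be only part of what the source reports. "The series", "measured", "known", "first", "only" and "open" are said of these compounds alone.

Compound 2 `CCCCNc1nc(N)nnc1OC` gives 2040 nM in an assay on isolated protein for agonist activity at Toll-like receptor 8 (Homo sapiens) (a lower number here means that less compound is needed, a higher number that more compound is needed for the effect), the highest of the two numbers; compound 1 `CCCCNc1nc(N)nnc1OCCCN(C)C` gives 100 nM. Within the data shown here, the single measured step, a 20-fold higher number from compound 1 to compound 2 (1.31 log units; beyond the scatter), shows that a substituent at this position lowered the number. Compound 3 `CCCCNc1nc(N)nnc1OCc1ccccn1` carries pyridin-2-yl in place of hydrogen on a saturated chain carbon bound to an oxygen on an aromatic ring. That step bears directly on the change in hand, but the entering group differs in kind, so a smaller lowering is expected: a 3.4-fold lower number from compound 2 to compound 3 (0.53 log units; beyond the scatter). For compound 3 the expected value in this assay is 600 nM, within 150 nM to 2500 nM.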

Compound 3, half-maximal effective concentration: 330 nM
For compound 3 the middle estimate is 1.8-fold (0.26 log units) above the measured one, and the stated range covers the measured number.
By their numbers in this assay, from the lowest: compound 1; then compound 3; then compound 2.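

On the saturated chain carbon bound to an oxygen on an aromatic ring, pyridin-2-yl also lowers the number in this assay (a 6.2-fold lower number from compound 2 to compound 3 (0.79 log units; beyond the scatter)), so the lowering is not confined to 2-(dimethylamino)ethyl. The two groups are not equivalent, however, as replacing 2-(dimethylamino)ethyl with pyridin-2-yl raises the number (a 3.3-fold higher number from compound 1 to compound 3 (0.52 log units; beyond the scatter)). No available evidence accounts for either step. The compounds shown leave open whether a phenyl ring would give the same lowering as pyridin-2-yl. They also leave open how pyridin-3-yl, or a longer chain ending in a dimethylamino group, would compare.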